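A few compounds are considered here, and "the series" means these few. Any claim that something is new, unique, unknown or untested is made for them only; others in the source may bear on it.

Four compounds sharing one core are followed here. Among the measured compounds shown here, compound 1 `O=C(Nc1cc(-c2nc3ccccc3s2)ccc1Cl)c1cc([N+](=O)[O-])ccc1Cl` is the first. In an ADME assay for permeability, using PAMPA, at pH 7.4 (on this read-out higher numbers stand for higher permeability and lower numbers for lower permeability), compound 1 gives "below limit of detection" (no number reported), so no single number stands for it. Compound 2 `Cc1ccc(-c2nc3ccccc3o2)cc1NC(=O)c1cc([N+](=O)[O-])ccc1Cl` in this assay gives "below limit of detection" (no number reported), again without a single number. Compound 3 `O=C(Nc1cccc(-c2nc3ccccc3s2)c1)c1cc([N+](=O)[O-])c(O)cc1Cl` in this assay gives 307 10^-6 cm/s. Compound 2 thus stands without a single number, and compound 1 is the only other entry in the same position. Compound 4 `O=C(Nc1cccc(-c2nc3ccccc3o2)c1)c1cc([N+](=O)[O-])ccc1Cl` differs from compound 2 by hydrogen in place of methyl on an aromatic carbon. For the measured compounds named here, no measured pair shows a step of this kind, and the missing number for compound 2 leaves both size and direction open; a step beyond the scatter in either direction cannot be ruled out. Compound 4 is expected to give 30 10^-6 cm/s, within 3 10^-6 cm/s to 300 10^-6 cm/s.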

Compound 4, apparent permeability in the ADME assay: 45 10^-6 cm/s
Compound 4: the middle estimate sits 1.5-fold (0.18 log units) below what was measured; low and high end bracket the measured number.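

Among the compounds shown here, compound 2 has no single number in the ADME assay, and no step to compound 4 can be read there. In a physicochemical assay for solubility, read by spectrophotometry, in phosphate buffer, measured as kinetic solubility, with a stated time of 18 h, at pH 7.4 (on this read-out lower numbers stand for lower solubility and higher numbers for higher solubility), compound 2 gives 310 nM and compound 4 gives 470 nM with a 1.5-fold higher number from compound 2 to compound 4 (0.18 log units; within the scatter). The compounds shown leave open what hydrogen in place of methyl on an aromatic carbon does in the ADME assay. No evidence shown bears on these results.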